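The compounds below may be only part of what the source reports. "The series", "measured", "known", "first", "only" and "open" are said of these compounds alone.

In a functional assay on the whole organism (ileum) with Rattus norvegicus as the target (a higher number here means a larger maximal response, a lower number a smaller maximal response), compound 1 `COc1cc(-c2nc3ccccc3[nH]2)ccc1O` gives 70%, compound 2 `COc1ccc(-c2nc3ccccc3[nH]2)cc1OC` gives 55%, and compound 3 `COc1ccc(-c2nc3ccccc3[nH]2)c(OC)c1OC` gives 65%. On the numbers as they stand, compound 2 has the lowest figure of the three, but its gap to compound 3, a number 10 percentage points higher from compound 2 to compound 3 (within the scatter), lies within the scatter, so those two cannot be ranked; only compound 1 stands clearly apart, a number 15 percentage points lower from compound 1 to compound 2 (beyond the scatter). Compound 4 `COc1cc(OC)c(-c2nc3ccccc3[nH]2)cc1OC` differs from compound 2 by methoxy in place of hydrogen on an aromatic carbon. Among the compounds with values here, the one measured step of the same kind in this assay is a number 10 percentage points higher from compound 2 to compound 3 (within the scatter), a change within the scatter. The step to compound 4 is therefore expected to be small, a number 5 percentage points higher from compound 2 to compound 4 (within the scatter), with no firm direction. Compound 4 is estimated at 60%, between 45% and 75%.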

Compound 4, largest response reached (Emax), in percent of the reference or control that the assay uses: 90%
The estimate for compound 4 lay 30 percentage points below the measured number; measured number outside the range, above it.
By their numbers in this assay, from the lowest: compounds 2, 3 and 1 (each within the scatter of the next, the first and the last beyond it); then compound 4.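

In this assay, methoxy in place of hydrogen on an aromatic carbon proves not to be a uniformly small change: ortho to a group of 9 heavy atoms, meta to a methoxy group and para to a methoxy group, it gives a number 35 percentage points higher from compound 2 to compound 4 (beyond the scatter) and thus a large step, against a number 10 percentage points higher from compound 2 to compound 3 (within the scatter) for the same exchange at another ring carbon. Across these two steps, the outcome depends on where the methoxy enters. No evidence accounts for this difference. Going by these compounds, whether an amine or a carboxylic acid on this same carbon would give a similar maximal response remains open.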